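This account rests on a few compounds, and the source may have more. Where it says the series, first, only, none or still open, it means among the compounds named here.

For the measured compounds named here, in an assay on a protein complex for inhibition of CDK8/Cyclin C (Homo sapiens), with a stated time of 1 h (on this read-out lower numbers stand for stronger inhibition and higher numbers for weaker inhibition), compound 1 `CNC(=O)/C=C/c1ccncc1-c1ccc2ccccc2c1` gives 12.4 nM, the lowest of the three numbers measured so far. Compound 2 `CNC(=O)/C=C/c1ccncc1-c1ccc2cc[nH]c2c1` gives 18.6 nM, which sits within the scatter of compound 1, so the two cannot be told apart. Compound 3 `Cn1ccc2cc(-c3cnccc3/C=C/C(=O)O)ccc21` gives 26.8 nM, a higher number than compound 1 that lies beyond the scatter. Compound 4 `O=C(/C=C/c1ccncc1-c1ccc2ccccc2c1)NC1CC1` has not yet been measured in this assay. It differs from compound 1 in one place: cyclopropyl in place of methyl on an amide-type nitrogen. Going by the values given here, no measured pair shows this change. Cyclopropyl in place of methyl on an amide-type nitrogen is a small change, and the expected step from compound 1 to compound 4 is a 1.2-fold higher number from compound 1 to compound 4 (0.08 log units; within the scatter), none beyond the scatter. Compound 4 is therefore expected to give about 15 nM, within a range from 6 nM to 40 nM.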

Compound 4, half-maximal inhibitory concentration: 40.1 nM
Compound 4: the middle estimate sits 2.7-fold (0.43 log units) below what was measured; the whole stated range lies below it.
By their numbers in this assay, from the lowest: compounds 1, 2, 3 and 4 (each within the scatter of the next, the first and the last beyond it).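

In this assay, cyclopropyl in place of methyl on an amide-type nitrogen gives a 3.2-fold higher number from compound 1 to compound 4 (0.51 log units; beyond the scatter) and so weakens inhibition. This nitrogen is therefore not indifferent to what it carries, and a change that looks small on paper can be large enough to read clearly. Nothing shown gives a reason for this step.

Going by these compounds, whether an ethyl group or a plain hydrogen on that nitrogen would stay close to compound 1 remains open. So does whether the same swap would have a similar effect on the core of compound 2.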